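The source may report more compounds than this note shows. Statements on the series, on what has been measured and on what is new or still open speak of the compounds shown alone.

Compound 1 `O=c1[nH]c(=O)n([C@@H]2O[C@H](CO)[C@@H](O)[C@H]2O)cc1C#CC1CCCCC1` is a nucleoside whose core carries a triple-bonded chain ending in a cyclohexyl ring. It was tested in an ADME assay on Vero cells (Chlorocebus sabaeus) for cytotoxicity, read by MTT assay (a lower number here means that less compound is tolerated, a higher number that more compound is tolerated), where compound 1 gives 148000 nM. Two simpler relatives have been measured alongside it. Compound 2 `O=c1[nH]cc(C#CC2CCCCC2)c(=O)[nH]1`, which lacks the sugar but keeps the cyclohexyl-capped triple bond, gives 247000 nM in this assay. Compound 3 `CCC#Cc1c[nH]c(=O)[nH]c1=O`, which has a shorter chain on the same core and no sugar, gives 263000 nM. All three values sit within the usual scatter of one another, so on the numbers shown compound 1 stands together with compound 2 and compound 3, and none of the three can be said to be tolerated better or worse than the others.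

Compound 4 `O=c1[nH]c(=O)n([C@@H]2O[C@H](CO)[C@@H](O)[C@H]2O)cc1C#CC(O)c1ccccc1` has not yet been measured. It keeps the sugar and the core of compound 1 and changes only the cap of the chain: hydroxy(phenyl)methyl in place of cyclohexyl on a triple-bonded carbon. Because compound 1 gives 148000 nM, compound 2 gives 247000 nM and compound 3 gives 263000 nM, all within the scatter although these three measured compounds differ far more from one another than compound 1 and compound 4 do, no step beyond the scatter is expected in this assay in either direction. The estimated step of a 1.2-fold higher number from compound 1 to compound 4 (0.09 log units; within the scatter) is small. Compound 4 is expected to give about 180000 nM, with a plausible range from 70000 nM to 400000 nM.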

Compound 4, half-maximal cytotoxic concentration: 65400 nM
Compound 4: the middle estimate sits 2.8-fold (0.44 log units) above what was measured, and the stated range ends above it.
By their numbers in this assay, from the lowest: compound 4; then compounds 1, 2 and 3 (each within the scatter of the next).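

In this assay, replacing the cap on the triple-bonded carbon gives a 2.3-fold lower number from compound 1 to compound 4 (0.35 log units; beyond the scatter), a modest step, but the first one shown here that clearly exceeds the scatter, so the group at this place can change how much compound the cells tolerate. The swap alters more than one feature at once: the non-aromatic cyclohexyl ring gives way to an aromatic ring, and the hydroxy(phenyl)methyl cap also adds a hydrogen-bond donor and acceptor, so this single pair cannot assign the step to any one feature. Nothing shown here offers a measured explanation for the step.

The compounds shown leave open whether the aromatic ring or the hydroxy group matters more, a question that a plain phenyl cap and a hydroxycyclohexyl cap on the same triple-bonded carbon could help separate. They also leave open whether an amine in place of the hydroxy group would give a similar number, and whether the same change of cap would have a similar effect on the core without the sugar.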